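The source may report more compounds than this note shows. Statements on the series, on what has been measured and on what is new or still open speak of the compounds shown alone.

Measured so far in a functional assay on Ramos cells (Homo sapiens) for antiproliferative activity, read by CCK-8 assay, with a stated time of 72 h, tested at 40 uM; on this read-out lower numbers stand for less inhibition and higher numbers for more inhibition at the one concentration tested (going by the name of the read-out):

Compound 1, `CN1CCN(c2ccc(Nc3nc(-c4cccc(NC(=O)c5cccc(F)c5)c4)sc3C(=O)O)cc2)CC1`: 82.7%
Compound 2, `CN1CCN(c2ccc(Nc3nc(-c4cccc(NC(=O)c5cccc(F)c5)c4)sc3C(N)=O)cc2)CC1`: 16.2%

Of the two numbers in this assay, compound 2 stands lowest; its nearest neighbour is compound 1, reached by a number 66.5 percentage points lower from compound 1 to compound 2 (beyond the scatter), a change of amino in place of hydroxy on a carbonyl carbon.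

Compound 3, `CN1CCN(c2ccc(Nc3nc(-c4cccc(NC(=O)[C@H]5CC[C@H](C)CC5)c4)sc3C(N)=O)cc2)CC1`, is not yet measured. It keeps the amide-type carbonyl of compound 2 and differs from it only by 4-methylcyclohexyl in place of 3-fluorophenyl on a carbonyl carbon. Within the data shown here, no measured step touches this position: the one step known, from compound 1 to compound 2, concerns a different carbonyl carbon and says nothing about the acyl group that is exchanged here. The expectation therefore rests on compound 2 alone, whose value in this assay is 16.2%, with wide uncertainty in both directions.

Compound 3 is estimated at 20% in this assay, within 5% to 50%, which means an expected step of a number 3.8 percentage points higher from compound 2 to compound 3 (within the scatter), not beyond the scatter.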

Compound 3, a percentage reported as inhibition, at one concentration (the size of the read-out at that concentration, not a potency): 55.1%
Estimate against measurement, compound 3: 35.1 percentage points below; measured number above the stated range.
By their numbers in this assay, from the lowest: compound 2; then compound 3; then compound 1.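

In this assay, the acyl group on the amide-type nitrogen proves to be a sensitive position, which the earlier step on the other carbonyl carbon could not show: exchanging 3-fluorophenyl for 4-methylcyclohexyl gives a number 38.9 percentage points higher from compound 2 to compound 3 (beyond the scatter). The two groups have the same heavy-atom count and neither has hydrogen-bond donors or acceptors, so the exchange replaces a six-membered aromatic ring bearing fluorine with a six-membered non-aromatic carbon ring with 2 defined stereocentres. Nothing available explains the size of this step.

As far as these compounds go, it remains open whether the exchange has a similar effect when the carboxylic acid of compound 1 is present. Plain cyclohexyl and unsubstituted phenyl on this carbonyl carbon would help separate the contribution of ring type from those of the methyl and the fluorine.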